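The source may report more compounds than this note shows. Statements on the series, on what has been measured and on what is new or still open speak of the compounds shown alone.

Of the compounds shown here, three built on a shared core have been measured in a functional assay on DU-145 cells (Homo sapiens) for inhibition, read by trypan blue exclusion, with a stated time of 72 h; on this read-out lower numbers stand for stronger inhibition and higher numbers for weaker inhibition. Compound 2 `Cn1c(=O)c(S(=O)(=O)c2ccc(F)cc2)cc2cnc(Nc3cnc4[nH]ccc4c3)nc21` gives 500 nM, the lowest of the three numbers. Compound 3 `Cn1c(=O)c(S(=O)(=O)c2ccc(F)cc2)cc2cnc(Nc3ccc4[nH]ncc4c3)nc21` gives 5000 nM, and compound 1 `Cn1c(=O)c(S(=O)(=O)c2ccccc2)cc2cnc(Nc3ccc4cc[nH]c4c3)nc21` gives 10000 nM. Among the compounds with values here, the only step between compounds that differ in a single place, a 10-fold higher number from compound 2 to compound 3 (1.00 log units; beyond the scatter), exchanges the group on the amine nitrogen and says nothing about the sulfonyl side. Compound 1 and compound 2 differ in two places at once, so their values can only be set side by side: together the two changes move the number well beyond the scatter, but the data do not say which change carries that movement.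

Compound 4 `Cn1c(=O)c(S(=O)(=O)c2ccccc2)cc2cnc(Nc3cnc4[nH]ccc4c3)nc21` has not yet been measured. It differs from compound 2 by hydrogen in place of fluoro on an aromatic carbon. Within the data shown here, no measured step covers this change, and the amine group of compound 4 is the same as that of compound 2, which gives 500 nM. With nothing in the measured steps pointing to a shift, compound 4 is expected to stay near the number of compound 2, and the step of a 1.4-fold higher number from compound 2 to compound 4 (0.15 log units; within the scatter) is expected to lie within the scatter. Compound 4 is therefore estimated at 700 nM, with a range from 300 nM to 2500 nM.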

Compound 4, half-maximal inhibitory concentration: 1000 nM
Compound 4: the middle estimate sits 1.4-fold (0.15 log units) below what was measured; low and high end bracket the measured number.
By their numbers in this assay, from the lowest: compounds 2 and 4 (each within the scatter of the next); then compounds 3 and 1 (each within the scatter of the next).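

Read alone, the exchange of 4-fluorophenyl for phenyl gives in this assay a 2.0-fold higher number from compound 2 to compound 4 (0.30 log units; within the scatter), so on this amine group the fluoro on this aromatic carbon can give way to hydrogen with no shift beyond the scatter. With phenylsulfonyl now held fixed, the amine group can be read on its own, and it gives a 10-fold lower number from compound 1 to compound 4 (1.00 log units; beyond the scatter); the large gap that earlier could only be set side by side across two changes therefore lies with the amine group, while the fluoro step stays within the scatter. No measurement shown accounts for either step.

From the compounds shown here alone, the fluoro and hydrogen pair has been read on a single amine group, so whether the two stay within the scatter of each other on the amine groups of compound 1 and compound 3 remains open. Also open, going by these compounds, is how a chloro, methoxy or nitrile on this same aromatic carbon would compare with the fluoro of compound 2 and the hydrogen of compound 4.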